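The source may report more compounds than this note shows. Statements on the series, on what has been measured and on what is new or still open speak of the compounds shown alone.

Three members of one series share the core seen in compound 1 `O=C(Nc1ncc(C(Oc2ccc3cc(Br)ccc3c2)c2ccc(Cl)cc2)s1)C1CC1` and differ only in the group carried on the nitrogen attached to the aromatic ring. In an ADME assay on HepG2 2.2.15 cells (Homo sapiens) for cytotoxicity (on this read-out lower numbers stand for higher toxicity in this test and higher numbers for lower toxicity in this test), compound 1 is recorded as "not toxic" (no number reported). Compound 2 `O=C(Nc1ncc(C(Oc2ccc3cc(Br)ccc3c2)c2ccc(Cl)cc2)s1)C1CCCO1` in this assay is likewise recorded as "not toxic" (no number reported). For compound 3 `N#Cc1cccc(C(=O)Nc2ncc(C(Oc3ccc4cc(Br)ccc4c3)c3ccc(Cl)cc3)s2)c1` this assay gives only a limit, > 50000 nM, not a measured number. Among the compounds with values here, compound 3 therefore stands at the edge of what this assay reports, and it shares that position with the two companions that carry no number at all; the one numerical entry in the set is the limit itself (the limit of > 50000 nM in this assay, at which 1 of the 3 values shown sits), so no step between measured compounds can be read from these data.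

Compound 4 `O=S(=O)(Nc1ncc(C(Oc2ccc3cc(Br)ccc3c2)c2ccc(Cl)cc2)s1)c1ccc(Cl)cc1` is obtained from compound 3 by the change ((4-chlorophenyl)sulfonyl in place of (3-cyanophenyl)carbonyl on a nitrogen on an aromatic ring). Since the two earlier compounds and compound 3 all sit at or beyond the reach of this assay, the step from compound 3 to compound 4 is expected to be a number no higher from compound 3 to compound 4 (the limit leaves the size open), that is, nothing beyond the usual scatter, with a modest chance of a small drop toward measurable toxicity. Compound 4 is accordingly expected to give about 50000 nM in this assay, within a range from 15000 nM to 150000 nM, and most likely to return only a limit once more.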

Compound 4, half-maximal cytotoxic concentration: "not toxic" (no number reported)
For compound 4 the study gives words and no number, so the estimate cannot be set against anything.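

In this assay, within the data shown here, compound 3 has only a limit and compound 4 only words, and no step between the two can be read. The compounds shown leave open whether changing the group on the nitrogen, including the (4-chlorophenyl)sulfonyl group of compound 4, alters cytotoxicity at all, as none of them has a measured number.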